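The compounds below may be only part of what the source reports. "The series", "measured", "known", "first", "only" and "open" are said of these compounds alone.

Measured in a functional assay on HO8910 cells (Homo sapiens) for inhibition, read by MTT assay, with a stated time of 24 h, tested at 10 ug/mL; on this read-out higher numbers stand for more inhibition of growth at the one concentration tested and lower numbers for less inhibition of growth:
compound 1 `O=C(CCCCC(S)CCS)Nc1ccc(OC(F)(F)F)cc1`: 6.11%
compound 2 `COc1ccc(NC(=O)CCCCC(S)CCS)cc1`: 4.14%

Compound 2 stands within the scatter of compound 1, and both numbers are small. Compound 3 `O=C(CCCCC(S)CCS)Nc1ccc([N+](=O)[O-])cc1` carries nitro in place of methoxy on an aromatic carbon, para to a large group: nitro in place of methoxy on an aromatic carbon. Going by the values given here, the only measured step that bears on this change is a number 2 percentage points lower from compound 1 to compound 2 (within the scatter). That step stays within the scatter, so no step beyond the scatter is expected in this assay, and no firm direction. The expected step is a number 1.9 percentage points higher from compound 2 to compound 3 (within the scatter). For compound 3 the estimate is 6%, with an expected range of 0% to 18%.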

Compound 3, percent growth inhibition at one concentration: 8.96%
Compound 3: middle estimate off by 3 percentage points, on the low side, and the stated range covers the measured number.
By their numbers in this assay, from the lowest: compounds 2, 1 and 3 (each within the scatter of the next).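

In this assay, nitro on this aromatic carbon, para to a large group, stays within the scatter of both methoxy and trifluoromethoxy: a number 4.8 percentage points higher from compound 2 to compound 3 (within the scatter), and a number 2.9 percentage points higher from compound 1 to compound 3 (within the scatter). Across these three groups at this position, no order can be read, so the position has not yet shown any response to a change of group. Nothing available bears on the cause of these numbers.

Going by these compounds, whether an amine or a carboxylic acid on this carbon would give a step beyond the scatter remains open. The same holds for a longer chain elsewhere on the shared core.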